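Replacing Methoxy with Methyl on the Shared Core

The compounds below may be only part of what the source reports. "The series", "measured", "known", "first", "only" and "open" are said of these compounds alone.

Compound 1, `COCCNc1nc(C)nc2c1nnn2-c1ccc(C(C)C)cc1Br`: 242 nM
Compound 2, `COCCCNc1nc(C)nc2c1nnn2-c1ccc(C(C)C)cc1Br`: 291 nM

In an in vitro assay on 293-EBNA cells for binding affinity to corticotropin-releasing factor receptor 1 (Homo sapiens) (a lower number here means a stronger inhibitor, a higher number a weaker inhibitor), compound 2 gives 291 nM, the higher of the two numbers shown, with compound 1 nearest at 242 nM. For the measured compounds named here, the only measured step, a 1.2-fold higher number from compound 1 to compound 2 (0.08 log units; within the scatter), lengthened the chain while keeping the methoxy. Compound 3, `CCCCNc1nc(C)nc2c1nnn2-c1ccc(C(C)C)cc1Br`, differs from compound 2 by methyl in place of methoxy on a saturated chain carbon, three bonds along the chain from a nitrogen on an aromatic ring. Going by the values given here, no measured step covers the loss of the oxygen, so the expectation rests on the small step seen so far. Compound 3 is estimated at 320 nM, between 110 nM and 950 nM. The expected step of a 1.1-fold higher number from compound 2 to compound 3 (0.04 log units; within the scatter) lies within the scatter.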

Compound 3, inhibition constant: 69.6 nM
Compound 3: the middle estimate sits 4.6-fold (0.66 log units) above what was measured; the whole stated range lies above it.
By their numbers in this assay, from the lowest: compound 3; then compounds 1 and 2 (each within the scatter of the next).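

In this assay, removing the oxygen matters where adding a chain carbon with the methoxy kept did not: methyl in place of methoxy gives a 4.2-fold lower number from compound 2 to compound 3 (0.62 log units; beyond the scatter), and ethyl in place of methoxy gives a 3.5-fold lower number from compound 1 to compound 3 (0.54 log units; beyond the scatter). Among these three compounds, butyl is thus the one chain that stands apart from both methoxy-bearing chains. Nothing available explains this difference. The compounds shown leave open whether a longer chain such as pentyl would go on lowering the number, or whether it would rise again. They also leave open how an amine in place of the methyl would compare.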